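Adding one chain carbon to compound 3

The source may report more compounds than this note shows. Statements on the series, on what has been measured and on what is new or still open speak of the compounds shown alone.

In a functional assay on Jurkat cells (Homo sapiens) for antiproliferative activity, read by MTT assay, with a stated time of 48 h (on this read-out lower numbers stand for stronger inhibition and higher numbers for weaker inhibition), compound 1 (`O=C(CCCCCCn1cc(Nc2ncc(Cl)c(Nc3cccc(Cl)c3)n2)cn1)NO`) gives 100 nM, compound 2 (`O=C(CCCCCCn1cc(Nc2ncc(Cl)c(Nc3ccccc3)n2)cn1)NO`) gives 90 nM and compound 3 (`O=C(CCCCCn1cc(Nc2ncc(Cl)c(Nc3ccc(Cl)cc3)n2)cn1)NO`) gives 60 nM. The value of compound 3 lies within the scatter of both others, so the three cannot be ranked.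

Compound 4 (`O=C(CCCCCCn1cc(Nc2ncc(Cl)c(Nc3ccc(Cl)cc3)n2)cn1)NO`) departs from compound 3 in its chain: (hydroxycarbamoyl)methyl in place of hydroxycarbamoyl on a saturated chain carbon, five bonds along the chain from an aromatic nitrogen. In words, (hydroxycarbamoyl)methyl stands in place of hydroxycarbamoyl on a saturated chain carbon, five bonds along the chain from an aromatic nitrogen.

Among the measured compounds shown here, the only measured step, a 1.1-fold lower number from compound 1 to compound 2 (0.05 log units; within the scatter), puts hydrogen in place of chloro on an aromatic carbon and stays within the scatter. For the measured compounds named here, it leaves the chain untouched, and no measured step changes the chain alone, so the evidence is indirect. Compounds 1 and 2 do carry the chain of compound 4. Compound 1 at 100 nM and compound 2 at 90 nM both lie within the scatter of compound 3 at 60 nM.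

A small move toward the numbers of those two compounds is therefore expected, and nothing larger. The estimated step, a 1.3-fold higher number from compound 3 to compound 4 (0.12 log units; within the scatter), stays within the scatter in this assay. For compound 4 the estimate is 80 nM, with an expected range of 40 nM to 160 nM.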

Compound 4, half-maximal inhibitory concentration: 100 nM
For compound 4 the middle estimate is 1.3-fold (0.10 log units) below the measured one; measured number inside the range.
By their numbers in this assay, from the lowest: compounds 3, 2, 1 and 4 (each within the scatter of the next).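

In this assay the chain change can now be read directly: a 1.7-fold higher number from compound 3 to compound 4 (0.22 log units; within the scatter) comes with (hydroxycarbamoyl)methyl in place of hydroxycarbamoyl, so on the 4-chlorophenyl compounds this extension at this position moves the number by no more than the usual scatter. With the longer chain held fixed, the aromatic changes also stay within the scatter: a 1.1-fold higher number from compound 2 to compound 4 (0.05 log units; within the scatter) comes with chloro in place of hydrogen on an aromatic carbon, and no change at the digits printed from compound 1 to compound 4 (within the scatter) comes with 4-chlorophenyl in place of 3-chlorophenyl on a nitrogen on an aromatic ring. No available evidence gives a reason for any of these steps.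

As far as these compounds go, the chain step rests on a single pair of compounds, so it remains open whether the same extension would stay within the scatter with phenyl or 3-chlorophenyl in place of 4-chlorophenyl, or whether a still longer chain would do so. The compounds shown also leave open what would follow if a carboxylic acid or a primary amide stood in place of hydroxycarbamoyl at the chain end.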